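The compounds below may be only part of what the source reports. "The series", "measured", "known", "first", "only" and "open" are said of these compounds alone.

Compound 1, with the structure `COc1ccc2c(=O)c(/C=C/C(=O)Nc3ccccc3Cl)coc2c1`, carries a 2-chlorophenyl group on its amide-type nitrogen. In a functional assay (QGY7701 cells, Homo sapiens) for inhibition, read by MTT assay, with a stated time of 48 h (a higher number here means a weaker inhibitor, a lower number a stronger inhibitor), compound 1 gives 23000 nM. Compound 2, with the structure `COc1ccc2c(=O)c(/C=C/C(=O)NCc3ccccc3F)coc2c1`, carries a 2-fluorobenzyl group there instead, and in this assay compound 2 gives 34000 nM; the change a 1.5-fold higher number from compound 1 to compound 2 (0.17 log units; within the scatter). Compound 3, with the structure `COc1ccc2c(=O)c(/C=C/C(=O)Nc3ccc(Cl)cc3)coc2c1`, carries a 4-chlorophenyl group on that nitrogen. In this assay compound 3 reaches only > 100000 nM, which is a limit of the assay and not a number, as shown by the limit of > 100000 nM in this assay, at which 1 of the 3 values shown sits. Compound 3 therefore stands at the weak end of the three measured compounds: the change an at least 4.3-fold higher number from compound 1 to compound 3 (0.63 log units; beyond the scatter), and the change an at least 2.9-fold higher number from compound 2 to compound 3 (0.46 log units; beyond the scatter).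

Compound 4, with the structure `COc1ccc2c(=O)c(/C=C/C(=O)Nc3ccc(F)cc3)coc2c1`, is not yet measured. It differs from compound 3 by fluoro in place of chloro on an aromatic carbon. Among the measured compounds shown here, none of the measured steps swaps one halogen for another on the same group; the two steps that bear on compound 3 both concern moving to or from the 4-chlorophenyl group, and both went toward weaker inhibition. With no measured halogen swap to lean on, the step that the limit leaves unreadable from compound 3 to compound 4 is expected to be small, within the scatter, and compound 4 is estimated to give about 120000 nM in this assay, with a range from 40000 nM to 400000 nM.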

Compound 4, half-maximal inhibitory concentration: > 100000 nM
Compound 4 was reported as a limit; the forecaster's own chance of this, stated with the estimate: 60%; the middle value lies beyond the limit too.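

In this assay compound 4 sits at a limit of the assay, not at a number, just as compound 3 does, so the step of fluoro in place of chloro on this aromatic carbon cannot be read, and neither can its size or direction: the limit of > 100000 nM in this assay, at which 2 of the 4 values shown sit.

What this adds is that the weak result is not tied to chloro, since a 4-fluorophenyl group on the amide-type nitrogen also stands clearly apart from the two groups with measured values, with the change an at least 4.3-fold higher number from compound 1 to compound 4 (0.63 log units; beyond the scatter) and the change an at least 2.9-fold higher number from compound 2 to compound 4 (0.46 log units; beyond the scatter). Among these four compounds, then, the 4-chlorophenyl and 4-fluorophenyl groups both give a limit, while the 2-chlorophenyl and 2-fluorobenzyl groups of compound 1 and compound 2 give measured values, and no compound shown goes against this.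

As far as these compounds go, how far compound 3 and compound 4 lie from each other remains open. Also open, from the compounds shown here alone, is what a methoxy group or an amine in place of the halogen on this aromatic carbon would do, and whether a 2-fluorophenyl group on the nitrogen would behave like the 2-chlorophenyl group of compound 1.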